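This account rests on a few compounds, and the source may have more. Where it says the series, first, only, none or still open, it means among the compounds named here.

Compound 1, with structure `O=c1c2cnn(-c3ccc(F)cc3)c2ncn1CC1(O)CCN(Cc2ccccc2F)CC1`, is the starting point of this comparison, and in an assay on Sf21 cells for inhibition of ubiquitin carboxyl-terminal hydrolase 7 (Homo sapiens), read by spectrophotometry, with stated times of 30 min and 2 h (on this read-out lower numbers stand for stronger inhibition and higher numbers for weaker inhibition), compound 1 gives 9800 nM. Within the data shown here, this is the only number in the set: of the two related compounds, compound 2 with structure `N#Cc1ccc(CN2CCC(O)(Cn3cnc4c(cnn4-c4ccc(F)cc4)c3=O)CC2)cc1` gives "not determined" (no result reported) there, and compound 3 with structure `COC(=O)c1cccc(CN2CCC(O)(Cn3cnc4c(cnn4-c4ccc(F)cc4)c3=O)CC2)c1` gives "not determined" (no result reported), so compound 1 stands alone and cannot be ranked against any neighbour.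

The compound now to be judged is compound 4, with structure `O=c1c2cnn(-c3ccc(F)cc3)c2ncn1CC1(O)CCN(Cc2ccc(Cl)cc2Cl)CC1`. It differs from compound 1 in a single place: 2,4-dichlorophenyl in place of 2-fluorophenyl on a saturated chain carbon bound to an amine nitrogen in a ring. Among the measured compounds shown here, no pair of measured compounds shows what such a change does here, so there is no measured step to lean on.

For the measured compounds named here, because the single value of compound 1 is 9800 nM and nothing else is known, the expectation for compound 4 is cautious: a step of a 2.0-fold lower number from compound 1 to compound 4 (0.29 log units; within the scatter) is estimated, modest and possibly within the scatter. Compound 4 is therefore expected to give about 5000 nM, with a likely range from 1500 nM to 20000 nM.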

Compound 4, half-maximal inhibitory concentration: 3300 nM
Compound 4: middle estimate off by 1.5-fold (0.18 log units), on the high side; the range from low to high includes it.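

Among these compounds, replacing 2-fluorophenyl with 2,4-dichlorophenyl on a saturated chain carbon bound to an amine nitrogen in a ring gives, in this assay, a 3.0-fold lower number from compound 1 to compound 4 (0.47 log units; beyond the scatter) as the first readable step in this set. It shows that the number responds to a change in this aryl group, and that a heavier, twice-chlorinated ring is accepted here without loss of inhibition. Nothing measured on hand accounts for the step, which therefore stands as an observation only.

Steps to compound 2 and compound 3 cannot be read, so one pair is all that speaks for this position. Going by these compounds, it remains open whether the step comes from either chlorine alone or from losing the fluorine, and what an unsubstituted phenyl, an amine or a carboxylic acid would do in this place.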